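The source may report more compounds than this note shows. Statements on the series, on what has been measured and on what is new or still open speak of the compounds shown alone.

Three compounds share one core and differ only in the group on a saturated chain carbon bound to an aromatic nitrogen: compound 1 (`Cc1ccc(Cn2c(=O)[nH]c3c(N)nc(C(F)(F)F)cc32)cn1`), compound 2 (`Cc1cccc(Cn2c(=O)[nH]c3c(N)nc(C(F)(F)F)cc32)n1`) and compound 3 (`Cc1cc(Cn2c(=O)[nH]c3c(N)nc(C(F)(F)F)cc32)no1`). In a physicochemical assay for lipophilicity, measured as octanol-water partition, at pH 7.4 (a higher number here means a more lipophilic compound, a lower number a more polar compound), compound 1 gives 2.3, compound 2 gives 2.3 and compound 3 gives 2.1, which places compound 3 within the scatter of both others.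

Compound 4 (`Cc1nc(Cn2c(=O)[nH]c3c(N)nc(C(F)(F)F)cc32)cs1`) carries 2-methyl-1,3-thiazol-4-yl in place of 5-methyl-1,2-oxazol-3-yl at that same place: 2-methyl-1,3-thiazol-4-yl in place of 5-methyl-1,2-oxazol-3-yl on a saturated chain carbon bound to an aromatic nitrogen. No thiazole in this set has been measured yet, so the evidence is indirect. The measured exchanges at this place are no change at the digits printed from compound 1 to compound 2 (within the scatter), a number 0.20 log units lower from compound 1 to compound 3 (within the scatter) and a number 0.20 log units lower from compound 2 to compound 3 (within the scatter). Going by these three steps, none of them beyond the scatter, no step beyond the scatter is expected in this assay for this exchange either. The estimated step is a number 0.20 log units higher from compound 3 to compound 4 (within the scatter). Compound 4 is expected at 2.3, with an estimated range of 2 to 2.7.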

Compound 4, distribution coefficient: 2.3
Estimate against measurement, compound 4: no gap at the digits printed; the range from low to high includes it.
By their numbers in this assay, from the lowest: compounds 3, 1, 2 and 4 (each within the scatter of the next).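

In this assay, the first thiazole at this place reads a number 0.20 log units higher from compound 3 to compound 4 (within the scatter), no change at the digits printed from compound 2 to compound 4 (within the scatter) and no change at the digits printed from compound 1 to compound 4 (within the scatter). With 2-methyl-1,3-thiazol-4-yl included, the four groups on a saturated chain carbon bound to an aromatic nitrogen, two methylpyridines and two five-membered aromatic rings, are linked only by steps within the scatter, and no compound among these four goes against that. The exchange of 5-methyl-1,2-oxazol-3-yl for 2-methyl-1,3-thiazol-4-yl, which swaps one oxygen for one sulfur in the atom count, comes with no evidence that could explain this reading.

The compounds shown leave open whether a carboxylic acid or an amine in place of these aromatic rings would give a step beyond the scatter. They also leave open what the thiazole without its methyl would read.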